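The source may report more compounds than this note shows. Statements on the series, on what has been measured and on what is new or still open speak of the compounds shown alone.

The compounds share one core, seen in compound 1 `CC[C@H](C)[C@H](NC(=O)c1cccc(Cn2ccnc2)c1)C(=O)NNS(=O)(=O)c1ccccc1`, and differ only in what sits on an amide-type nitrogen. In an assay on HEK293 cells for displacement of a labelled ligand from Type-2 angiotensin II receptor (Homo sapiens), tested at 10 uM (on this read-out lower numbers stand for a weaker effect and higher numbers for a stronger effect at the one concentration tested), compound 1 gives 18%. Compound 2 `CC[C@H](C)[C@H](NC(=O)c1cccc(Cn2ccnc2)c1)C(N)=O`, carrying an unsubstituted amide there, is reported in this assay as "not active" (no number reported), without a number. Compound 3 `CC[C@H](C)[C@H](NC(=O)c1cccc(Cn2ccnc2)c1)C(=O)NC#N` gives 9% in this assay. Among the measured compounds shown here, of the two numbers that exist, compound 3 holds the lower one, and its nearest neighbour is compound 1; the single step between them, a number 9 percentage points lower from compound 1 to compound 3 (within the scatter), lies within the scatter, so the two cannot be told apart on this read-out.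

Compound 4 `CC[C@H](C)[C@H](NC(=O)c1cccc(Cn2ccnc2)c1)C(=O)NO` has not yet been measured. It differs from compound 3 in one place: hydroxy in place of cyano on an amide-type nitrogen. For the measured compounds named here, the only measured step touching the same amide-type nitrogen is a number 9 percentage points lower from compound 1 to compound 3 (within the scatter), and it was small. Going by the values given here, no measured compound carries a hydroxy on that amide-type nitrogen, so the expectation rests on the fact that both variations tried there gave low numbers. The expected step, a number 1 percentage points higher from compound 3 to compound 4 (within the scatter), is therefore none beyond the scatter. Compound 4 is estimated to give 10% in this assay, between 0% and 25%.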

Compound 4, a percentage reported as inhibition, at one concentration (the size of the read-out at that concentration, not a potency): 4%
Beside the measured number, compound 4's estimate is 6 percentage points above it; the measured number falls inside the stated range.
By their numbers in this assay, from the lowest: compounds 4, 3 and 1 (each within the scatter of the next, the first and the last beyond it).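

In this assay this amide-type nitrogen now shows its first separation that exceeds the scatter, a number 14 percentage points lower from compound 1 to compound 4 (beyond the scatter), so hydroxy and (phenylsulfonyl)amino can be told apart there, although the gap is modest and cyano cannot be separated from either of them on its own steps. The exchange of cyano for hydroxy, which replaces a group without a hydrogen-bond donor by one that has one, gives only a number 5 percentage points lower from compound 3 to compound 4 (within the scatter), so at this position the two small groups cannot be told apart on this read-out. No measurement shown here explains these differences at the amide-type nitrogen.

The compounds shown leave open whether the phenyl or the sulfonyl part of (phenylsulfonyl)amino accounts for the separation from hydroxy, and what a methoxy, a plain phenyl or a longer chain on that nitrogen would give. They also leave open whether any group at this place can raise the number well clear of this low range, and how changes elsewhere on the shared core would read at the one concentration tested.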